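The compounds below may be only part of what the source reports. "The series", "measured", "known", "first", "only" and "open" are said of these compounds alone.

Measured so far in a functional assay on CEM-SS cells (Homo sapiens) for cytotoxicity; a higher number here means a weaker inhibitor, a lower number a stronger inhibitor:
- compound 1 `Nc1nc2cc(Cl)c(Cl)cc2n1Cc1cccc(Cl)c1`: 37000 nM
- compound 2 `Clc1ccc(Cn2c(Br)nc3cc(Cl)c(Cl)cc32)cc1Cl`: > 100000 nM

Compound 2 has no number on this scale: in this assay compound 2 reads > 100000 nM, which is a limit of the assay. This is the limit of > 100000 nM in this assay, at which 1 of the 2 values shown sits.

Compound 3 `Clc1cccc(Cn2c(Br)nc3cc(Cl)c(Cl)cc32)c1` comes from compound 2 through one change, hydrogen in place of chloro on an aromatic carbon. Going by the values given here, no measured pair shows this change alone, so the expected size of the step rests on thin ground. A modest move towards a lower number is expected, though a reading that again reaches the limit remains quite possible. Among the compounds with values here, the only support is compound 1, which also carries hydrogen at that place but differs elsewhere too, and which gives 37000 nM. The expected step is an at least 1.5-fold lower number from compound 2 to compound 3 (0.18 log units; that floor lies within the scatter). For compound 3 the estimated value is 65000 nM, with an expected range of 28000 nM to 140000 nM.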

Compound 3, half-maximal inhibitory concentration: > 100000 nM
Compound 3 gave a limit, no number; the forecaster's own chance of this, stated with the estimate: 45%; middle value at least 1.5-fold (0.18 log units) away from the limit.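

In this assay, hydrogen in place of chloro on an aromatic carbon, ortho to a chloro group, leaves the reading at the limit, and the step from compound 2 to compound 3 cannot be read because both values are limits and not numbers: the limit of > 100000 nM in this assay, at which 2 of the 3 values shown sit. Going by these compounds alone, compound 3 also gives the first comparison that differs in one place, where bromo in place of amino on an aromatic carbon brings an at least 2.7-fold higher number from compound 1 to compound 3 (0.43 log units; beyond the scatter). Among these three compounds, a reading on the scale therefore goes with the amino group on the core and not with the loss of the chloro, although only compound 1 carries that amino group, so this rests on a single value.

Within the data shown here, what the chloro at this position does when the core carries amino remains open, as the change has been seen only with bromo on the core. Also open, on these data alone, is whether another group in place of the bromo, such as a methylamino group or a carboxylic acid, would give a number on the scale in this assay as the amino group does.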